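Styryl aryl variation on the shared quinazoline-free core series

A few compounds are considered here, and "the series" means these few. Any claim that something is new, unique, unknown or untested is made for them only; others in the source may bear on it.

Measured compounds:
compound 1 `COc1cc2nc(/C=C/c3cccnc3)nc(N3CCC(CCNS(N)(=O)=O)CC3)c2cc1OC` — 58 nM
compound 2 `COc1cc2nc(/C=C/c3ccncc3)nc(N3CCC(CCNS(N)(=O)=O)CC3)c2cc1OC` — 218 nM
compound 3 `COc1cc2nc(/C=C/c3ccc(F)cc3)nc(N3CCC(CCNS(N)(=O)=O)CC3)c2cc1OC` — 465 nM

All three share one core and differ only in the aryl group on the double-bonded chain carbon bound to a double-bonded chain carbon. In an assay on cells for inhibition of Ectonucleotide pyrophosphatase/phosphodiesterase family member 1 (Homo sapiens), with a stated time of 60 min (a lower number here means a stronger inhibitor, a higher number a weaker inhibitor), compound 1 gives 58 nM. Compound 2 gives 218 nM and compound 3 gives 465 nM. Compound 3 stands highest of the three; the steps of an 8.0-fold higher number from compound 1 to compound 3 (0.90 log units; beyond the scatter) and a 2.1-fold higher number from compound 2 to compound 3 (0.33 log units; beyond the scatter) both lie beyond the scatter, as does a 3.8-fold higher number from compound 1 to compound 2 (0.58 log units; beyond the scatter).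

Compound 4 `COc1ccccc1/C=C/c1nc(N2CCC(CCNS(N)(=O)=O)CC2)c2cc(OC)c(OC)cc2n1` is not yet measured. The change from compound 3 is 2-methoxyphenyl in place of 4-fluorophenyl on a double-bonded chain carbon bound to a double-bonded chain carbon. Within the data shown here, none of the measured steps swaps one carbon-only ring for another; all three involve a pyridyl. Among the measured compounds shown here, they show only that the aryl group here moves the number modestly in either direction. A step of comparable size, not more, is expected, with no basis to set its direction.

Compound 4 is expected to give about 350 nM in this assay, within 120 nM to 1100 nM, so that a 1.3-fold lower number from compound 3 to compound 4 (0.12 log units; within the scatter) is the estimated step.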

Compound 4, inhibition constant: 302 nM
The estimate for compound 4 lay 1.2-fold (0.06 log units) above the measured number; measured number inside the range.
By their numbers in this assay, from the lowest: compound 1; then compounds 2, 4 and 3 (each within the scatter of the next, the first and the last beyond it).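

In this assay, among these compounds, 2-methoxyphenyl in place of 4-fluorophenyl is the first swap at this position of one carbon-only ring for another, and a 1.5-fold lower number from compound 3 to compound 4 (0.19 log units; within the scatter) does not separate the two groups. The step of a 1.4-fold higher number from compound 2 to compound 4 (0.14 log units; within the scatter) leaves 2-methoxyphenyl equally unresolved from pyridin-4-yl, so compounds 2, 3 and 4 do not differ by a clear margin in any step that includes compound 4. Only pyridin-3-yl stands apart from 2-methoxyphenyl, with a 5.2-fold higher number from compound 1 to compound 4 (0.72 log units; beyond the scatter) beyond the scatter, and compound 1 now has the lowest number against three other aryl groups.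

Nothing measured here accounts for the separate standing of the pyridin-3-yl compound.

Still open, from the compounds shown here alone, is how an amine or a carboxylic acid on the phenyl ring would read at this position.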